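The source may report more compounds than this note shows. Statements on the series, on what has been measured and on what is new or still open speak of the compounds shown alone.

Of the compounds shown here, three on the shared core have numbers so far. Among the measured compounds shown here, in an ADME assay on microsomes from liver (Rattus norvegicus) for metabolic stability (a higher number here means that the compound lasts longer, a lower number that the compound disappears faster), compound 1 (`CC#C[C@@H](Cc1nnn[nH]1)c1ccc(OCc2ccc3scc(-c4cccnc4C)c3c2)cc1`) gives 0.183 h which lies within the scatter of compound 3 (`CC#C[C@@H](Cc1nnn[nH]1)c1ccc(OCc2ccc3sc(C)c(-c4ccc(OCCOC)cc4C)c3c2)cc1`) at 0.117 h and clearly under compound 2 (`CC#C[C@@H](Cc1nnn[nH]1)c1ccc(OCc2ccc3scc(-c4ccc(OCCCS(C)(=O)=O)cc4C)c3c2)cc1`) at 1.48 h as the one number that stands apart from the others.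

Compound 4 (`CC#C[C@@H](Cc1nnn[nH]1)c1ccc(OCc2ccc3scc(C4CC4)c3c2)cc1`) keeps the core of compound 1 and alters one group. The change is cyclopropyl in place of 2-methylpyridin-3-yl on an aromatic carbon on an aromatic carbon of a five-membered aromatic ring with 1 sulfur, two ring bonds from the ring sulfur.

For the measured compounds named here, no two measured compounds differ in one place only, and no measured compound carries a cyclopropyl group, so the data give no direct guide to this step. The closest reference is compound 1 itself at 0.183 h with compound 3 at 0.117 h showing a similarly short half-life on a different substitution. On that basis no step beyond the scatter is expected in this assay in either direction. The expected outcome is a 1.1-fold higher number from compound 1 to compound 4 (0.04 log units; within the scatter) and the uncertainty is wide. For compound 4 the estimate is 0.2 h with a range from 0.08 h to 0.55 h expected.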

Compound 4, half-life: 1.72 h
Beside the measured number, compound 4's estimate is 8.6-fold (0.93 log units) below it, and the stated range ends below it.
By their numbers in this assay, from the lowest: compounds 3 and 1 (each within the scatter of the next); then compounds 2 and 4 (each within the scatter of the next).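

In this assay, cyclopropyl in place of 2-methylpyridin-3-yl on an aromatic carbon of the five-membered aromatic ring with 1 sulfur, two ring bonds from the ring sulfur, gives a 9.4-fold higher number from compound 1 to compound 4 (0.97 log units; beyond the scatter). This is the only pair shown that differs in one place, and it shows that the half-life responds to the group at this position: a six-membered aromatic ring is not required there, and a smaller, carbon-only three-membered ring is compatible with the higher number. Nothing measured on these compounds speaks to the reason for this step.

A single pair cannot separate the effect of introducing cyclopropyl from that of removing 2-methylpyridin-3-yl, so it remains open which of the two accounts for the step. Groups such as methyl, cyclobutyl, or an unsubstituted phenyl at the same place would show whether the higher number follows the size of the group, the non-aromatic ring, or the absence of the ring nitrogen.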